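A few compounds are considered here, and "the series" means these few. Any claim that something is new, unique, unknown or untested is made for them only; others in the source may bear on it.

Compound 1, `Cc1ccc(-n2nncc2CN2C(=O)C3(C(C#N)=C(N)Oc4c(N)cc5nc6ccccc6nc5c43)c3ccccc32)cc1C`, in a functional assay on A549 cells (Homo sapiens) for antiproliferative activity, read by MTT assay, with a stated time of 48 h (a lower number here means a stronger inhibitor, a higher number a weaker inhibitor), reaches only a limit for compound 1 of > 50000 nM.
Compound 2, `COc1ccc(OC)c(-n2nncc2CN2C(=O)C3(C(C#N)=C(N)Oc4c(N)cc5nc6ccccc6nc5c43)c3ccccc32)c1`, in this assay gives compound 2 a number of 28100 nM.

Compound 2 thus holds the only number shown in this assay; the other value shown is a limit (the limit of > 50000 nM in this assay, at which 1 of the 2 values shown sits). Within the data shown here, the one measured step, an at least 1.7-fold lower number from compound 1 to compound 2 (0.25 log units; that floor lies within the scatter), exchanges one aryl group on the aromatic nitrogen for another and reports only a floor that sits within the scatter. Compound 3, `N#CC1=C(N)Oc2c(N)cc3nc4ccccc4nc3c2C12C(=O)N(Cc1cnnn1-c1ccc([N+](=O)[O-])cc1[N+](=O)[O-])c1ccccc12`, differs from compound 2 by 2,4-dinitrophenyl in place of 2,5-dimethoxyphenyl on an aromatic nitrogen. Among the measured compounds shown here, that earlier step is the only one bearing on this change, and it gives no sign that swapping aryl groups on that nitrogen moves the number beyond the scatter. Compound 3 is therefore expected to stay near compound 2, with a step of a 1.1-fold higher number from compound 2 to compound 3 (0.03 log units; within the scatter) that lies within the scatter, and an estimated value of 30000 nM between 10000 nM and 60000 nM.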

Compound 3, half-maximal inhibitory concentration: > 50000 nM
Compound 3 was reported as a limit (the forecaster's own chance of this, stated with the estimate: 35%); at least 1.6-fold (0.22 log units) between middle value and limit.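

In this assay, placing 2,4-dinitrophenyl on the aromatic nitrogen gives an at least 1.7-fold higher number from compound 2 to compound 3 (0.25 log units; that floor lies within the scatter), so a second aryl exchange at this position also shows no change that can be placed beyond the scatter. Three differently substituted phenyl groups have now stood on this nitrogen, and only compound 2 with its 2,5-dimethoxyphenyl group carries a number, while the other two compounds share a limit: the limit of > 50000 nM in this assay, at which 2 of the 3 values shown sit. The step between compound 1 and compound 3 cannot be read, as both of its values are limits.

The compounds shown leave open how far compound 1 and compound 3 lie from compound 2 in real terms. They also leave open whether an aminophenyl group, a benzyl group or a short alkyl chain on this nitrogen would move the number clearly beyond the scatter.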